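This account rests on a few compounds, and the source may have more. Where it says the series, first, only, none or still open, it means among the compounds named here.

In an ADME assay on MT4 cells (Homo sapiens) for cytotoxicity, read by MTT assay, with a stated time of 4 days (a higher number here means that more compound is tolerated, a lower number that less compound is tolerated), compound 1 `Cc1ccccc1OCCn1ccc(=O)n(Cc2ccccc2)c1=O` gives 117000 nM. Compound 3 `N#Cc1ccc(OCCn2ccc(=O)n(Cc3ccccc3)c2=O)cc1`, at 166000 nM, lies within the scatter of it, and compound 2 `O=c1ccn(CCOc2ccc(Cl)cc2)c(=O)n1Cc1ccccc1`, at 36000 nM, sits at the low end of the set. Compound 4 `Cc1cc(C)cc(OCCn2ccc(=O)n(Cc3ccccc3)c2=O)c1` brings (3,5-dimethylphenyl in place of 2-methylphenyl on an oxygen on a saturated carbon), with 3,5-dimethylphenyl in place of 2-methylphenyl. Among the measured compounds shown here, the steps that bear on it alter the group at the same place: a 3.3-fold lower number from compound 1 to compound 2 (0.51 log units; beyond the scatter), a 1.4-fold higher number from compound 1 to compound 3 (0.15 log units; within the scatter) and a 4.6-fold higher number from compound 2 to compound 3 (0.66 log units; beyond the scatter). For the measured compounds named here, no measured step exchanges one methyl-bearing phenyl for another, so no change beyond the scatter is expected in this assay. The expected step is a 1.3-fold lower number from compound 1 to compound 4 (0.11 log units; within the scatter). For compound 4 the estimated value is 90000 nM, with an expected range of 40000 nM to 170000 nM.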

Compound 4, half-maximal cytotoxic concentration: 46000 nM
Compound 4: the middle estimate sits 2.0-fold (0.29 log units) above what was measured; the measured number falls inside the stated range.
By their numbers in this assay, from the lowest: compounds 2 and 4 (each within the scatter of the next); then compounds 1 and 3 (each within the scatter of the next).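

In this assay, this position responds to a carbon-only aryl group as well: with no chloro or cyano present, the move to 3,5-dimethylphenyl gives a change beyond the scatter (a 2.5-fold lower number from compound 1 to compound 4 (0.41 log units; beyond the scatter)). The same group also separates from the nitrile-bearing aryl (a 3.6-fold lower number from compound 3 to compound 4 (0.56 log units; beyond the scatter)), whereas it stays within the scatter of the chloro-bearing aryl (a 1.3-fold higher number from compound 2 to compound 4 (0.11 log units; within the scatter)). Nothing available here explains these steps. Open, from the compounds shown here alone, is how an amine or a carboxylic acid on the phenyl would read, and whether a longer chain to the oxygen would shift the number.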